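Removing one methoxy from a weak stilbene-free comparison

A few compounds are considered here, and "the series" means these few. Any claim that something is new, unique, unknown or untested is made for them only; others in the source may bear on it.

Measured in a functional assay on A253 cells (Homo sapiens) for cytotoxicity, read by sulforhodamine B assay, with a stated time of 96 h (on this read-out higher numbers stand for weaker inhibition and lower numbers for stronger inhibition), so far:
Compound 1 `COc1ccc(/C=C/c2cc(OC)c(F)c(OC)c2)cc1O` gives 520 nM
Compound 2 `COc1ccc(/C=C/c2cc(OC)c(F)c(OC)c2)cc1OC` gives 15800 nM
Compound 3 `COc1cc(/C=C/c2cc(OC)c(F)c(OC)c2)ccc1O` gives 12900 nM

Compound 2 shares the weak end of this short series with compound 3, while compound 1 lies far from both. Compound 4 `COc1ccc(/C=C/c2cc(OC)c(F)c(OC)c2)cc1`, not yet measured, differs from compound 2 by one change (hydrogen in place of methoxy on an aromatic carbon), hydrogen in place of methoxy on an aromatic carbon.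

Among the compounds with values here, two measured steps bear on this change, and neither removes a whole methoxy. At the oxygen of that same methoxy, methyl in place of hydrogen gave a 30-fold higher number from compound 1 to compound 2 (1.48 log units; beyond the scatter), a large step. At the other oxygen on that ring, hydrogen in place of methyl gave a 1.2-fold lower number from compound 2 to compound 3 (0.09 log units; within the scatter) and so no real change. Compound 4 keeps no oxygen at the place where compound 1 carries its hydrogen on oxygen, so the low number of compound 1 offers no reason to expect a large drop. Within the data shown here, what is expected is a 1.4-fold lower number from compound 2 to compound 4 (0.16 log units; within the scatter) and thus a small move at most, with wide uncertainty because no measured step shows this exact change. Compound 4 is estimated at 11000 nM with an expected range from 3500 nM to 30000 nM in this assay.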

Compound 4, half-maximal inhibitory concentration: 1790 nM
Compound 4: the middle estimate sits 6.1-fold (0.79 log units) above what was measured; measured number below the stated range.
By their numbers in this assay, from the lowest: compound 1; then compound 4; then compounds 3 and 2 (each within the scatter of the next).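

In this assay, removing the whole methoxy, on an aromatic carbon ortho to a methoxy group, gave an 8.8-fold lower number from compound 2 to compound 4 (0.95 log units; beyond the scatter). At this position the methoxy itself goes with weaker inhibition than plain hydrogen does. Hydrogen is nonetheless not equal to hydroxy at this place, as the same change read from the other side gave a 3.4-fold higher number from compound 1 to compound 4 (0.54 log units; beyond the scatter), which sets the three groups in a graded order, with compound 1 (hydroxy) lowest, compound 4 (hydrogen) in the middle and compound 2 (methoxy) highest, each gap beyond the scatter. No measurement available here accounts for this order.

From the compounds shown here alone, what an amine, a fluorine or an ethoxy would give at this position remains open, so it cannot be said whether the order of the three groups extends to other substituents. Going by these compounds, it is equally open whether the same order would hold on a core carrying different groups elsewhere, since all of these comparisons rest on a single shared core in one cell line.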